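The source may hold more compounds than are shown below. What is called first, only, known or untested is meant among the compounds shown, and "the series" means these compounds.

Compound 1, `COc1ccc(C2=NN(C3=NC(=O)/C(=C4\C(=O)Nc5ccc(Br)cc54)S3)C(c3ccc(OC)cc3)C2)cc1`, gives 480 nM in a functional assay on cells (Cancer cell lines, Homo sapiens) for cytotoxicity, read by sulforhodamine B assay, with a stated time of 48 h; on this read-out higher numbers stand for weaker inhibition of growth and lower numbers for stronger inhibition of growth.
Compound 2, `COc1ccc(C2=NN(C3=NC(=O)/C(=C4\C(=O)Nc5ccc(Cl)cc54)S3)C(c3ccc(OC)cc3)C2)cc1`, gives 500 nM in this assay.
Compound 3, `COc1ccc(-c2cc(-c3ccc(Cl)cc3)n(C3C(=O)Nc4ccc(Br)cc43)n2)cc1`, gives 24600 nM in this assay.

Compound 1 and compound 2 share one core and differ by a single change, (chloro in place of bromo on an aromatic carbon), which produced a 1.0-fold higher number from compound 1 to compound 2 (0.02 log units; within the scatter). Compound 3 is built on another core; the difference between the two cores is not broken down here. Its number in this assay stands beyond the scatter from both compound 1 and compound 2, and is the highest of the three.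

Compound 4, `COc1ccc(-c2cc(-c3ccc(Cl)cc3)n(C3C(=O)Nc4ccc(Cl)cc43)n2)cc1`, is yet to be measured in this assay. It stands to compound 3 as compound 2 stands to compound 1: chloro in place of bromo on an aromatic carbon, the same change at a place described in the same words. Because a 1.0-fold higher number from compound 1 to compound 2 (0.02 log units; within the scatter) lay within the scatter, the step of a 1.0-fold higher number from compound 3 to compound 4 (0.01 log units; within the scatter) is expected to be similarly small. Compound 4 is therefore estimated at 25000 nM, with a likely range from 12000 nM to 50000 nM.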

Compound 4, concentration for total growth inhibition: 17800 nM
For compound 4 the middle estimate is 1.4-fold (0.15 log units) above the measured one, and the stated range covers the measured number.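

Chloro in place of bromo on an aromatic carbon gave a 1.4-fold lower number from compound 3 to compound 4 (0.14 log units; within the scatter) in this assay, so on the core of compound 3 this change again left the number within the scatter. The two steps agree within the scatter of two such steps: the same change on two cores in this assay, a 1.0-fold higher number (0.02 log units; within the scatter) from compound 1 to compound 2 and a 1.4-fold lower number (0.14 log units; within the scatter) from compound 3 to compound 4, 1.4-fold (0.16 log units) apart, within the scatter of two such steps This shows that the change carried across these two cores without a step beyond the scatter, but it does not show that the same would hold on any other core, nor does it show that either halogen is better than the other.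

The compounds shown leave open what a fluoro, a methyl, a methoxy or an amine at this place would give. They also leave open whether any such group would move the number beyond the scatter on either core.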